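A few compounds are considered here, and "the series" means these few. Any claim that something is new, unique, unknown or untested is made for them only; others in the source may bear on it.

Measured so far:
compound 1, `COc1cc(N)c(Cl)cc1NC(=O)C1CCN(CC2CC2)CC1`: > 10 mg/kg
compound 2, `COc1cc(N)c(Cl)cc1NC(=O)C1CCN(Cc2ccc(Cl)cc2)CC1`: 1.2 mg/kg
compound 3, `CCOc1ccc(CN2CCC(C(=O)Nc3cc(Cl)c(N)cc3OC)CC2)cc1`: 6.3 mg/kg

In a functional assay on the whole organism for antagonist activity, with Mus musculus as the target (on this read-out lower numbers stand for an effect already at smaller amounts and higher numbers for an effect only at larger amounts of compound), compound 1 has no number of its own, only a limit, > 10 mg/kg, since it sits at the limit of > 10 mg/kg in this assay, at which 1 of the 3 values shown sits. Compound 4, `COc1ccc(CN2CCC(C(=O)Nc3cc(Cl)c(N)cc3OC)CC2)cc1`, differs from compound 1 as follows: 4-methoxyphenyl in place of cyclopropyl on a saturated chain carbon bound to an amine nitrogen in a ring.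

Two measured steps start from compound 1 and replace the same cyclopropyl with an aryl group. With 4-chlorophenyl: an at least 8.3-fold lower number from compound 1 to compound 2 (0.92 log units; beyond the scatter). With 4-ethoxyphenyl: an at least 1.5-fold lower number from compound 1 to compound 3 (0.20 log units; that floor lies within the scatter). Between those two aryl groups, a 5.3-fold higher number from compound 2 to compound 3 (0.72 log units; beyond the scatter). The 4-methoxyphenyl of compound 4 carries an oxygen substituent like the 4-ethoxyphenyl of compound 3 rather than the chloro of compound 2, so a step from the limit of compound 1 of the size seen for compound 3, at most somewhat larger, is expected in this assay. The expected step is an at least 2.5-fold lower number from compound 1 to compound 4 (0.39 log units; beyond the scatter). Compound 4 is therefore estimated at 4 mg/kg, with a range from 1.5 mg/kg to 10 mg/kg.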

Compound 4, dose for half-maximal effect: 0.9 mg/kg
Estimate against measurement, compound 4: 4.4-fold (0.65 log units) above; the measured number lies below the stated range.
By their numbers in this assay, from the lowest: compounds 4 and 2 (each within the scatter of the next); then compound 3. At a limit, above all of these: compound 1.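

On this position, 4-methoxyphenyl in place of cyclopropyl in this assay gives an at least 11-fold lower number from compound 1 to compound 4 (1.04 log units; beyond the scatter). Compound 1 enters that step only as a limit: the limit of > 10 mg/kg in this assay, at which 1 of the 4 values shown sits. An oxygen substituent on the aryl group therefore does not by itself carry the weaker number of compound 3: hydrogen in place of methyl on the saturated chain carbon bound to an oxygen gives a 7.0-fold lower number from compound 3 to compound 4 (0.85 log units; beyond the scatter), while methoxy in place of chloro gives a 1.3-fold lower number from compound 2 to compound 4 (0.12 log units; within the scatter), which leaves compounds 2 and 4 indistinguishable.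

With only methoxy and ethoxy, the compounds shown leave open how the number changes along the alkoxy chain, for example with propoxy or with a hydroxyl in place of the methoxy. Also open, going by these compounds, is whether an amine or a carboxylic acid would be accepted on this aryl group.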